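The source may report more compounds than this note shows. Statements on the series, on what has been measured and on what is new or still open speak of the compounds shown alone.

Compound 1 `CCCCCNc1nc(N)c2nc(O)n(Cc3ccccc3)c2n1`: 0.1 uM
Compound 2 `Nc1ncnc2c1nc(O)n2-c1ccccc1`: > 10 uM
Compound 3 `NNc1nc2c(N)ncnc2n1Cc1ccccc1`: > 10 uM

These three compounds were tested in a functional assay (spleen, spleen) for activation, with Mus musculus as the target; a lower number here means that less compound is needed, a higher number that more compound is needed for the effect. Going by the values given here, compound 1 gives the only full number, 0.1 uM. For compound 2 the result is a limit of this assay, > 10 uM, not a number. For compound 3 the result is likewise a limit, > 10 uM. Among the compounds with values here, two of the three results thus sit at the assay limit (the limit of > 10 uM in this assay, at which 2 of the 3 values shown sit), so compound 1 stands alone as the one with a measured value.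

Compound 4 `CCCCCSc1nc(N)c2nc(O)n(Cc3ccccc3)c2n1` is not yet measured. It differs from compound 1 in one place: pentylsulfanyl in place of pentylamino on an aromatic carbon. The pentylamino group, with its one hydrogen-bond donor, gives way to pentylsulfanyl, which has none. Within the data shown here, no measured pair shows how such a change plays out here. A moderate loss is expected in this assay, a 3.0-fold higher number from compound 1 to compound 4 (0.48 log units; beyond the scatter), though not certainly beyond the scatter. Compound 4 is estimated at 0.3 uM, in the range 0.05 uM to 3 uM.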

Compound 4, minimum effective concentration: 10 uM
Estimate against measurement, compound 4: 33-fold (1.52 log units) below, outside the stated range (above it).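

Going by these compounds alone, the first measured pair in this assay shows that this position, on an aromatic carbon between two ring nitrogen atoms, is highly sensitive to the atom linking the chain to the shared core: pentylsulfanyl in place of pentylamino gives a 100-fold higher number from compound 1 to compound 4 (2.00 log units; beyond the scatter). The chain itself stays the same, while the hydrogen-bond donor of pentylamino is lost. Nothing measured here explains the size of this loss.

Going by these compounds, it remains open whether the donor or the sulfur atom matters more. A pentyloxy chain or a methyl(pentyl)amino group would help separate these two possibilities.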